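The source may report more compounds than this note shows. Statements on the series, on what has been measured and on what is new or still open speak of the compounds shown alone.

Two related compounds have been measured in a functional assay on NCI-H460 cells (Homo sapiens) for antiproliferative activity; a higher number here means a weaker inhibitor, a lower number a stronger inhibitor. In this test, compound 1 (`Cn1cc(C2=C(c3c[nH]c4cc(Br)ccc34)C(=O)NC2=O)c2ccccc21`) gives 970 nM and compound 2 (`Cn1cc(C2=C(c3cn(C)c4ccccc34)C(=O)NC2=O)c2ccccc21`) gives 2440 nM. Compound 2 therefore holds the higher, weaker number of the pair, and the gap between them lies beyond the usual scatter. Compound 3 (`Cn1cc(C2=C(c3cn(CC(O)CO)c4ccccc34)C(=O)NC2=O)c2ccccc21`) differs from compound 2 in one place: 1,2-dihydroxyethyl in place of hydrogen on a saturated chain carbon bound to an aromatic nitrogen. This puts 1,2-dihydroxyethyl in place of hydrogen on a saturated chain carbon bound to an aromatic nitrogen, which turns methyl into 2,3-dihydroxypropyl. Going by the values given here, no measured pair shows the effect of this change in this assay, so the expectation rests only on compound 2 at 2440 nM. No shift beyond the scatter is expected, and the estimated step is a 1.2-fold lower number from compound 2 to compound 3 (0.09 log units; within the scatter). For compound 3 the estimated value is 2000 nM, with an expected range from 600 nM to 7000 nM.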

Compound 3, half-maximal inhibitory concentration: 6600 nM
Beside the measured number, compound 3's estimate is 3.3-fold (0.52 log units) below it, and the stated range covers the measured number.
By their numbers in this assay, from the lowest: compound 1; then compound 2; then compound 3.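

In this assay, replacing the methyl of compound 2 with the 2,3-dihydroxypropyl of compound 3 gives a 2.7-fold higher number from compound 2 to compound 3 (0.43 log units; beyond the scatter) and so counts as a modest loss, since the step lies beyond the scatter. Going by these compounds alone, this is the first reading of any change on the saturated chain carbon bound to an aromatic nitrogen, and it shows that the longer chain weakens the compound without abolishing activity, as compound 3 still gives 6600 nM in this test. Nothing measured here accounts for the loss.

The compounds shown leave open whether the chain length or its two hydroxyl groups matter more, which a plain propyl chain would help to separate. On these data alone, how an amine or a carboxylic acid at the chain end would read also remains open.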